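Carbamate Selenocyanates: Adding a Methoxy Group

The compounds below may be only part of what the source reports. "The series", "measured", "known", "first", "only" and "open" are said of these compounds alone.

Measured so far:
compound 1 `C=CCOC(=O)Nc1ccc([Se]C#N)cc1`: 72800 nM
compound 2 `N#C[Se]c1ccc(NC(=O)Oc2ccccc2)cc1`: 71700 nM

In a functional assay on HT-29 cells (Homo sapiens) for cytotoxicity, read by MTT assay, with a stated time of 72 h (a higher number here means that more compound is tolerated, a lower number that less compound is tolerated), compound 2 gives 71700 nM, and the step of a 1.0-fold lower number from compound 1 to compound 2 (0.01 log units; within the scatter) shows that this sits within the scatter of compound 1. Compound 3 `COc1ccc(OC(=O)Nc2ccc([Se]C#N)cc2)cc1` carries one change: methoxy in place of hydrogen on an aromatic carbon. Within the data shown here, the single measured step, which swapped phenyl for allyl on the carbamate oxygen, was within the scatter and touched a different part of the molecule, so it bears on the new change only loosely. The expectation is therefore no step beyond the scatter, a 1.0-fold lower number from compound 2 to compound 3 (0.01 log units; within the scatter). Compound 3 is estimated at 70000 nM, with a range from 35000 nM to 140000 nM.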

Compound 3, concentration lethal to 50% of the cells: 69600 nM
Compound 3: middle estimate off by 1.0-fold (0.00 log units), on the high side; measured number inside the range.
By their numbers in this assay, from the lowest: compounds 3, 2 and 1 (each within the scatter of the next).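

In this assay the methoxy in place of hydrogen, on an aromatic carbon and para to a large group, gives a small step (a 1.0-fold lower number from compound 2 to compound 3 (0.01 log units; within the scatter)). This is the first change shown on this ring, since the earlier step touched the carbamate oxygen, and this position takes the methoxy with no shift beyond the scatter. No measurement on hand accounts for this outcome.

Going by these compounds, whether an amine, a carboxylic acid or a longer chain at this place would move the number remains open.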